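The source may report more compounds than this note shows. Statements on the series, on what has been measured and on what is new or still open speak of the compounds shown alone.

Compound 1, `CC(C)Cc1ccc(C(C)C(=O)NCc2ccc(Cl)cc2)cc1`, gives 27000 nM in an assay on brain for inhibition of Fatty-acid amide hydrolase 1 (Rattus norvegicus), read by scintillation counting, with a stated time of 10 min; on this read-out higher numbers stand for weaker inhibition and lower numbers for stronger inhibition.
Compound 2, `CC(C)Cc1ccc(C(C)C(=O)NCc2ccc(Cl)c(Cl)c2)cc1`, gives 36000 nM in this assay.
Compound 3, `CC(C)Cc1ccc(C(C)C(=O)N2CCN(c3cccc(Cl)c3)CC2)cc1`, gives 1700 nM in this assay.

Among these three, compound 3 stands lowest, and so is the strongest inhibitor shown: the nearest to it is compound 1, whose number is higher, and the furthest is compound 2, whose number is higher still, both gaps beyond the usual scatter. For the measured compounds named here, the only measured step that changes a single spot is a 1.3-fold higher number from compound 1 to compound 2 (0.12 log units; within the scatter), which tells only that adding a halogen to the aromatic ring on the amide side of that series barely moved the number.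

Compound 4, `CC(C)Cc1ccc(C(C)C(=O)N2CCN(c3ccc(F)cc3)CC2)cc1`, has not yet been measured. It differs from compound 3 by 4-fluorophenyl in place of 3-chlorophenyl on an amine nitrogen in a ring. Going by the values given here, no measured step swaps one halogen for another or moves a halogen around its ring, so the step from compound 1 to compound 2 bears on it only loosely, and it was within the scatter. On that basis a step from compound 3 to compound 4 of only modest size is expected in this assay, with a lean toward a somewhat higher number, as a 1.5-fold higher number from compound 3 to compound 4 (0.17 log units; within the scatter) expresses. For compound 4 the estimate is therefore 2500 nM, expected to fall between 700 nM and 9000 nM.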

Compound 4, half-maximal inhibitory concentration: 17000 nM
For compound 4 the middle estimate is 6.8-fold (0.83 log units) below the measured one; the measured number lies above the stated range.
By their numbers in this assay, from the lowest: compound 3; then compounds 4, 1 and 2 (each within the scatter of the next, the first and the last beyond it).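

In this assay, the halogen-bearing phenyl group on the ring nitrogen proves to be a sensitive spot: replacing 3-chlorophenyl with 4-fluorophenyl gives a 10-fold higher number from compound 3 to compound 4 (1.00 log units; beyond the scatter), a clear weakening of inhibition from a swap that leaves the size of the group, counted in heavy atoms, unchanged. For the compounds shown here, the only earlier single-place step, a 1.3-fold higher number from compound 1 to compound 2 (0.12 log units; within the scatter), lay in a different part of the molecule and stayed within the scatter, so it gave no sign that a halogen change could matter this much anywhere on these molecules. Nothing available here accounts for the size of this step, which changes both the halogen and its place on the ring, so the data cannot say which of the two matters.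

A compound with fluorine where compound 3 carries its chlorine, or one with chlorine where compound 4 carries its fluorine, would be needed to pull those two changes apart. The compounds shown also leave open how a plain phenyl group with no halogen, or a phenyl ring carrying a methoxy group or a nitrile, would behave on this ring nitrogen.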